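The source may hold more compounds than are shown below. What is called first, only, known or untested is meant among the compounds shown, and "the series" means these compounds.

Working notes on the series.

Among the measured compounds shown here, compound 1 `N#Cc1ccc(Cn2cc(COc3ccc(C#N)cc3)nn2)cc1` is one of three compounds measured in an assay on isolated protein for inhibition of Aromatase (Homo sapiens), read by fluorescence and colorimetric assay, with a stated time of 30 min; on this read-out lower numbers stand for stronger inhibition and higher numbers for weaker inhibition; compound 1 gives 9160 nM. Compound 2 `c1ccc(Cn2cc(COc3ccccc3)nn2)cc1` carries no substituent on the aryl ether ring and in this assay compound 2 gives 10600 nM. Compound 3 `Clc1ccc(OCc2cn(Cc3ccccc3)nn2)cc1` carries a chloro at that position; in this assay compound 3 gives 5040 nM, the lowest of the three numbers, though compound 1 sits within the scatter of it, so no order between compound 3 and compound 1 can be read. For the measured compounds named here, the one single-point step so far is a 2.1-fold lower number from compound 2 to compound 3 (0.32 log units; beyond the scatter).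

Compound 4 `N#Cc1ccc(OCc2cn(Cc3ccccc3)nn2)cc1` has not yet been measured. It differs from compound 3 in one place: cyano in place of chloro on an aromatic carbon. Going by the values given here, no measured step swaps chloro for cyano directly. The step from compound 2 to compound 3 tells only what adding chloro did. Compound 1 bears a cyano at the same place of the aryl ether ring, alongside a second cyano on the benzyl ring, and its number stands within the scatter of compound 3; that is the closest comparison available.

For compound 4 in this assay the expectation is therefore a number close to compound 3, with a step of a 1.3-fold higher number from compound 3 to compound 4 (0.11 log units; within the scatter) expected, within the scatter. The estimate for compound 4 is 6500 nM, expected to lie between 3000 nM and 14000 nM.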

Compound 4, half-maximal inhibitory concentration: 1360 nM
Beside the measured number, compound 4's estimate is 4.8-fold (0.68 log units) above it; the whole stated range lies above it.
By their numbers in this assay, from the lowest: compound 4; then compounds 3, 1 and 2 (each within the scatter of the next, the first and the last beyond it).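

At this position, on an aromatic carbon para to a large group, the nature of the substituent matters and not merely its presence: in this assay, cyano in place of chloro gives a 3.7-fold lower number from compound 3 to compound 4 (0.57 log units; beyond the scatter), and cyano in place of hydrogen gives a 7.8-fold lower number from compound 2 to compound 4 (0.89 log units; beyond the scatter), against a 2.1-fold lower number from compound 2 to compound 3 (0.32 log units; beyond the scatter) for chloro in place of hydrogen. The second cyano on the benzyl ring, absent from the newly measured compound, also counts: hydrogen in place of that cyano gives a 6.7-fold lower number from compound 1 to compound 4 (0.83 log units; beyond the scatter), so the nearness of the earlier cyano-bearing compound to the chloro compound said little about cyano at this position taken alone. The data shown offer no measured basis for explaining any of these steps.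

Open, going by these compounds, is whether cyano on the benzyl ring alone, with a bare aryl ether ring, would shift the number in the same direction as it does in the pair at hand. Also open, on these data alone, is how a methoxy, a nitro or a carboxylic acid at this position would compare with cyano.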